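Moving the Ring Nitrogen in an Isoquinoline Urea

This account rests on a few compounds, and the source may have more. Where it says the series, first, only, none or still open, it means among the compounds named here.

Of the compounds shown here, three sharing one core have been measured in an assay on CHO cells for antagonist activity at transient receptor potential cation channel subfamily V member 1 (Homo sapiens), read by scintillation counting, with a stated time of 5 min, in the presence of a further agent that is not named here; on this read-out lower numbers stand for an effect already at smaller amounts and higher numbers for an effect only at larger amounts of compound. Compound 1 `CN(C)C1(Cc2ccccc2)CCN(c2cc(C(F)(F)F)ccc2CNC(=O)Nc2cccc3c2CC(O)CC3)CC1` gives 10.1 nM. Compound 2 `CN(C)C1(Cc2ccccc2)CCN(c2cc(C(F)(F)F)ccc2CNC(=O)Nc2cccc3[nH]c(=O)ccc23)CC1` gives 30.6 nM. Compound 3 `CN(C)C1(Cc2ccccc2)CCN(c2cc(C(F)(F)F)ccc2CNC(=O)Nc2ccc3ccncc3c2)CC1` gives 56.1 nM, the highest number of the three: the step of a 5.6-fold higher number from compound 1 to compound 3 (0.74 log units; beyond the scatter) lies beyond the scatter, while the step of a 1.8-fold higher number from compound 2 to compound 3 (0.26 log units; within the scatter) does not, so compound 2 and compound 3 cannot be told apart on these numbers.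

Compound 4 `CN(C)C1(Cc2ccccc2)CCN(c2cc(C(F)(F)F)ccc2CNC(=O)Nc2ccc3cnccc3c2)CC1` has not yet been measured. It differs from compound 3 only in the two-ring group on the urea: isoquinolin-6-yl in place of isoquinolin-7-yl on an amide-type nitrogen. The two compounds contain the same atoms, joined differently.

Going by the values given here, none of the measured steps moves a ring nitrogen from one position to another; each exchanges one whole group for another. The steps of a 3.0-fold higher number from compound 1 to compound 2 (0.48 log units; beyond the scatter) and a 5.6-fold higher number from compound 1 to compound 3 (0.74 log units; beyond the scatter) show that replacing the group on the amide-type nitrogen can shift the number by a modest amount, and the step of a 1.8-fold higher number from compound 2 to compound 3 (0.26 log units; within the scatter) shows that two related two-ring groups can land within the scatter of each other. Shifting the nitrogen within the same ring system is a smaller alteration than any of these, so the step from compound 3 to compound 4 is expected to be small, a 1.1-fold lower number from compound 3 to compound 4 (0.05 log units; within the scatter), with no direction favoured. Compound 4 is therefore estimated at 50 nM, in the range 15 nM to 160 nM in this assay.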

Compound 4, half-maximal effective concentration: 156 nM
The estimate for compound 4 lay 3.1-fold (0.49 log units) below the measured number, and the stated range covers the measured number.
By their numbers in this assay, from the lowest: compound 1; then compounds 2 and 3 (each within the scatter of the next); then compound 4.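

In this assay the two isoquinoline isomers can be told apart: isoquinolin-6-yl in place of isoquinolin-7-yl on the amide-type nitrogen gives a clear change (a 2.8-fold higher number from compound 3 to compound 4 (0.44 log units; beyond the scatter)), although the two groups have the same atoms and the same counts of hydrogen-bond donors and acceptors. Going by these compounds alone, the earlier steps all exchanged one whole group for another, so this is the first sign here that a rearrangement within one two-ring group can alone carry a step beyond the scatter. It also sets compound 4 apart from the other compounds (a 5.1-fold higher number from compound 2 to compound 4 (0.71 log units; beyond the scatter); a 15-fold higher number from compound 1 to compound 4 (1.19 log units; beyond the scatter)), the latter being the largest step in this set, whereas compound 2 and compound 3 could not be told apart.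

No separate measurement bears on this difference, so the reason for it remains unknown. Also open, as far as these compounds go, is whether a naphthalen-2-yl group, with carbon in place of the ring nitrogen, would fall nearer compound 3 or compound 4, and whether the same isoquinoline change would give a similar step on a different core.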